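The compounds below may be only part of what the source reports. "The series", "measured", "known", "first", "only" and "open" are said of these compounds alone.

In a functional assay on C6 cells (Rattus norvegicus) for cytotoxicity, read by MTT assay, with a stated time of 24 h, tested at 50 ug/mL (on this read-out lower numbers stand for a stronger effect and higher numbers for a weaker effect at the one concentration tested), the three measured compounds gave these numbers:

compound 1, `Cc1ccc(-c2cs/c(=N/NC(=O)CSc3nnnn3-c3ccccc3)n2-c2ccccc2)cc1`: 29.5%
compound 2, `Cc1ccc(-c2cs/c(=N/NC(=O)CSc3nncn3C)n2-c2ccccc2)cc1`: 53.8%
compound 3, `Cc1ccc(-c2cs/c(=N/NC(=O)CSc3nnnn3C)n2-c2ccccc2)cc1`: 44.3%

Compound 3 has the second highest of the three numbers. Its gap to compound 2, a number 9.5 percentage points lower from compound 2 to compound 3 (within the scatter), is within the scatter, so the two cannot be told apart; its gap to compound 1, a number 14.8 percentage points higher from compound 1 to compound 3 (beyond the scatter), is beyond the scatter, so compound 3 is clearly weaker than compound 1 at this concentration.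

The unmeasured compound 4, `Cn1nnnc1SCC(=O)N/N=c1/scc(-c2ccc(C#N)cc2)n1-c1ccccc1`, differs from compound 3 in one place: cyano in place of methyl on an aromatic carbon.

Among the compounds with values here, none of the measured steps touches this part of the molecule. The steps of a number 24.3 percentage points higher from compound 1 to compound 2 (beyond the scatter) and a number 14.8 percentage points higher from compound 1 to compound 3 (beyond the scatter) both concern the ring on the sulfur or the group on the aromatic nitrogen, and the step of a number 9.5 percentage points lower from compound 2 to compound 3 (within the scatter) is within the scatter. The group that is swapped here has stayed the same across all three measured compounds, so nothing shown tells how this assay responds to it. The expectation is therefore no step beyond the scatter, a number 0.3 percentage points lower from compound 3 to compound 4 (within the scatter), with a wide range to allow for the unknown. Compound 4 is estimated at 44% in this assay, with a range from 20% to 70%.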

Compound 4, a percentage reported as activity, at one concentration (the size of the read-out at that concentration, not a potency): 35.6%
Beside the measured number, compound 4's estimate is 8.4 percentage points above it, and the stated range covers the measured number.
By their numbers in this assay, from the lowest: compounds 1, 4, 3 and 2 (each within the scatter of the next, the first and the last beyond it).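

Among the compounds shown, only this pair changes the group on the six-membered aromatic ring, para to a large group, so it gives the only reading on that position. In this assay, going from 4-methylphenyl to 4-cyanophenyl gives a number 8.7 percentage points lower from compound 3 to compound 4 (within the scatter), so the two compounds cannot be told apart at this concentration, even though the swap brings in a triple bond and a hydrogen-bond acceptor. At this one concentration, the position therefore accepts a cyano group in place of a methyl group with no shift beyond the usual scatter, and nothing shown offers an explanation of this result.

As far as these compounds go, whether an amine, a carboxylic acid or a longer chain on this same carbon would move the number beyond the scatter remains open. Also open, from the compounds shown here alone, is whether the same swap from methyl to cyano would give a similar result with the 1-phenyl-1H-tetrazol-5-yl group of compound 1 or the 4-methyl-4H-1,2,4-triazol-3-yl group of compound 2 on the sulfur.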